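A few compounds are considered here, and "the series" means these few. Any claim that something is new, unique, unknown or untested is made for them only; others in the source may bear on it.

The measured compounds and their values:
compound 1, `Nc1ncn(CCC2(N)OC(=O)C(OCc3ccccc3)=C2OCc2ccccc2)c(=O)n1`, in a functional assay on MCF7 cells (Homo sapiens) for inhibition, read by MTT assay, with a stated time of 72 h (on this read-out higher numbers stand for weaker inhibition and lower numbers for stronger inhibition), gives > 100000 nM
compound 2, `O=C1O/C(=C\Cn2ccc(NC(=O)c3ccccc3)nc2=O)C(OCc2ccccc2)=C1OCc1ccccc1`, in this assay gives 2030 nM
compound 3, `NC1(CCn2ncc(=O)[nH]c2=O)OC(=O)C(OCc2ccccc2)=C1OCc1ccccc1`, in this assay gives > 100000 nM

Compound 3 stands at a limit of the assay rather than at a number; its value sits at the limit of > 100000 nM in this assay, at which 2 of the 3 values shown sit. The value of compound 1 is likewise a limit and not a number. The step that the two limits leave unreadable from compound 1 to compound 3 is therefore unreadable in size and direction. Within the data shown here, compound 2 differs from compound 3 in more than one place, so its numerical value shows only that a compound of this shared core can give a readable inhibition in this assay.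

Compound 4, `NC1(CCn2cc(F)c(=O)[nH]c2=O)OC(=O)C(OCc2ccccc2)=C1OCc1ccccc1`, differs from compound 3 by a group of 9 heavy atoms (4 carbon, 2 nitrogen, 2 oxygen, 1 fluorine; one six-membered aromatic ring with 2 hetero atoms) in place of a group of 8 heavy atoms (3 carbon, 3 nitrogen, 2 oxygen; one six-membered aromatic ring with 3 hetero atoms), on a saturated chain carbon, two bonds along the chain from a saturated ring carbon. Among the measured compounds shown here, no measured step involves this particular change, and the one step that touches the same place is unreadable, so nothing here indicates a direction or a size. Compound 4 is therefore expected to stay near the limit, with a step of a number no higher from compound 3 to compound 4 (the limit leaves the size open). The estimate for compound 4 is 100000 nM, within a range from 20000 nM to 300000 nM.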

Compound 4, half-maximal inhibitory concentration: 20900 nM
Estimate against measurement, compound 4: 4.8-fold (0.68 log units) above, within the range that was stated.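

In this assay, the group on the saturated chain carbon, two bonds along the chain from a saturated ring carbon, can move the read-out: the group with 2 hetero atoms in its ring and one fluorine gives an at least 4.7-fold lower number from compound 3 to compound 4 (0.67 log units; beyond the scatter). Among these compounds, the same group, set against the one in compound 1, gives an at least 4.7-fold lower number from compound 1 to compound 4 (0.67 log units; beyond the scatter), so compound 4 is the first compound here in which a change at this place alone yields a number rather than a limit. The true size of both steps stays unknown, because each starts from a limit: the limit of > 100000 nM in this assay, at which 2 of the 4 values shown sit.

Going by these compounds, it remains open whether a hydrogen, chlorine or methyl in place of the fluorine on this ring would give the same number, so the step cannot be assigned to the fluorine alone. Also open, on these data alone, is how a longer chain carrying this ring would read.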